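The compounds below may be only part of what the source reports. "The series", "measured", "known", "first", "only" and "open" are said of these compounds alone.

Compound 1 `COc1ccc(COc2ccc3c(Cn4ccnc4)cc(=O)oc3c2)cc1OC` gives 57 nM in an assay on V79MZh11B1 cells for inhibition of cytochrome P450 11B1, mitochondrial (Homo sapiens), read by HPLC, with a stated time of 25 min; a higher number here means a weaker inhibitor, a lower number a stronger inhibitor.
Compound 2 `CC(C)Oc1ccc(COc2ccc3c(Cn4ccnc4)cc(=O)oc3c2)cc1` gives 48 nM in this assay.

Among these two numbers, compound 1 holds the highest value in this assay. Its nearest neighbour is compound 2, whose value lies within the scatter of compound 1, so the two cannot be told apart on potency. Compound 3 `COc1cccc(COc2ccc3c(Cn4ccnc4)cc(=O)oc3c2)c1` has not yet been measured in this assay. It differs from compound 1 in one place: hydrogen in place of methoxy on an aromatic carbon, that is, a hydrogen in place of a methoxy on an aromatic carbon of the six-membered aromatic ring of carbon only, ortho to a methoxy group and para to a large group. Among the compounds with values here, no step between measured compounds shows what such a change does here. Since compound 1 and compound 2 both carry an oxygen substituent on the aromatic carbon para to the large group and give similar values, losing that group is expected to cost some potency, but only a modest rise in the number. The estimate for compound 3 is 100 nM, with a range from 40 nM to 250 nM, an expected step of a 1.8-fold higher number from compound 1 to compound 3 (0.24 log units; within the scatter).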

Compound 3, half-maximal inhibitory concentration: 48 nM
Estimate against measurement, compound 3: 2.1-fold (0.32 log units) above; measured number inside the range.
By their numbers in this assay, from the lowest: compounds 2, 3 and 1 (each within the scatter of the next).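

In this assay, hydrogen in place of methoxy on an aromatic carbon, para to a large group and ortho to a methoxy group, comes out as a 1.2-fold lower number from compound 1 to compound 3 (0.07 log units; within the scatter) and so gives no measurable difference in potency. Until now, both measured compounds carried an oxygen substituent on this carbon, so nothing showed whether a value in this range depended on having one there; this step shows that, in the setting of compound 1, the methoxy on this carbon can be exchanged for hydrogen with no effect that can be told from the scatter. No measurement available here bears on why this change makes so little difference.

The compounds shown leave open what an amine, a carboxylic acid or a longer chain on this carbon would do, as methoxy and hydrogen are the only pair that can be compared here in a single step. They also leave open whether the methoxy that remains on compound 3 could be exchanged for hydrogen with as little consequence.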